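Swapping a Side Group on a Non-Toxic Compound

The source may report more compounds than this note shows. Statements on the series, on what has been measured and on what is new or still open speak of the compounds shown alone.

compound 1 `O=C(Nc1ccc(F)c(-c2nc3ccccc3o2)c1)c1cc([N+](=O)[O-])ccc1Cl`: > 25000 nM
compound 2 `Cc1ccc(-c2nc3ccccc3s2)cc1NC(=O)c1cc([N+](=O)[O-])c(N2CCC(C(=O)O)CC2)cc1Cl`: > 25000 nM
compound 3 `O=C(Nc1nc2ccc(Cl)cc2s1)c1cc([N+](=O)[O-])ccc1Cl`: > 27000 nM

All three entries are limits of the assay and not numbers. For the measured compounds named here, they come from an ADME assay on BJ cells (Homo sapiens) for cytotoxicity, with a stated time of 72 h (a lower number here means that less compound is needed, a higher number that more compound is needed for the effect), so no compound here has yet given a true reading.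

Compound 2 stands at > 25000 nM in this assay, and this value is a limit. It shares that limit with one other compound, as the line the limit of > 25000 nM in this assay, at which 2 of the 3 values shown sit, records. Going by the values given here, no two of the three compounds differ in just one place, so no measured step offers a guide to the next change.

Compound 4 `Cc1ccc(-c2nc3ccccc3s2)cc1NC(=O)c1cc([N+](=O)[O-])c(N(C)C)cc1Cl` keeps the core of compound 2 and makes one swap: dimethylamino in place of 4-carboxypiperidin-1-yl on an aromatic carbon. The new group sits ortho to a nitro group and meta to a chloro group.

The expectation rests on compound 2, whose > 25000 nM is a limit. In this assay, no step beyond the usual scatter is expected, and any drift is expected toward a lower number. The expected change, an at least 1.1-fold lower number from compound 2 to compound 4 (0.05 log units; that floor lies within the scatter), is therefore small. For compound 4 the estimated value is 22000 nM, with an expected range from 9000 nM to 30000 nM.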

Compound 4, half-maximal effective concentration: > 25000 nM
Compound 4 gave a limit, no number; the forecaster's own chance of this, stated with the estimate: 65%; middle value at least 1.1-fold (0.05 log units) away from the limit.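

In this assay compound 4 gives > 25000 nM, which is a limit and not a number. Compound 2 also stands at a limit, and the step between these two compounds cannot be read. The compounds shown leave open what concentration, if any, would give a true reading, and whether swapping the side group changes it at all.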